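The source may report more compounds than this note shows. Statements on the series, on what has been measured and on what is new or still open speak of the compounds shown alone.

Of the compounds shown here, two have so far been measured in an assay on PBMC cells for antagonist activity at Toll-like receptor 4 (Homo sapiens), read by HTRF, with stated times of 30 min and 20 h; a lower number here means a stronger inhibitor, a higher number a weaker inhibitor. Compound 1 `Cc1cc(-c2ccc(=O)n(C)c2)cc2cnc(N3CCN(C(C)C)CC3)nc12` gives 5900 nM, while compound 2 `Cc1cc(-c2ccc(=O)n(C)c2)cc2cn(C3CCNCC3)nc12` gives 1600 nM, the lower of the two numbers, and the gap between them lies beyond the usual scatter, so compound 2 is the stronger inhibitor of this pair. Compound 3 `Cc1cc(-c2cc(C)c3nn(C4CCNCC4)cc3c2)cn(C)c1=O` has not yet been measured. It differs from compound 2 in one place: methyl in place of hydrogen on an aromatic carbon. For the measured compounds named here, no measured pair here shows what such an addition does, so only a small step is expected, in either direction or none beyond the scatter. For compound 3 the expected result in this assay is 1500 nM, with a likely range from 600 nM to 4000 nM. The estimated step is a 1.1-fold lower number from compound 2 to compound 3 (0.03 log units; within the scatter).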

Compound 3, half-maximal inhibitory concentration: 250 nM
The estimate for compound 3 lay 6.0-fold (0.78 log units) above the measured number; measured number outside the range, below it.
By their numbers in this assay, from the lowest: compound 3; then compound 2; then compound 1.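

Placing a methyl on an aromatic carbon of the six-membered aromatic ring with 1 nitrogen gives a 6.4-fold lower number from compound 2 to compound 3 (0.81 log units; beyond the scatter) in this assay and shows that this position responds strongly to substitution. The step lies beyond the scatter, although the change adds only one carbon, with no hydrogen-bond donor or acceptor and no net charge. Nothing measured here bears on the reason for this gain.

The compounds shown leave open whether an ethyl group, a chlorine atom or a methoxy group at this position would keep the gain, extend it or lose it.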